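The source may report more compounds than this note shows. Statements on the series, on what has been measured and on what is new or still open speak of the compounds shown alone.

Working notes on the series. All three measured compounds were run in an ADME assay on Huh-7 cells (Homo sapiens) for cytotoxicity, with a stated time of 72 h (a lower number here means that less compound is tolerated, a higher number that more compound is tolerated), and none returned a number. Compound 1 `CS(=O)(=O)Nc1ccc2c(c1)S(=O)(=O)N=C(C1=C(O)C3CCCC3N(Cc3ccccn3)C1=O)N2` gives only a limit in this assay, > 33000 nM. Compound 2 `CS(=O)(=O)Nc1ccc2c(c1)S(=O)(=O)N=C(C1=C(O)[C@@H]3CCCC[C@@H]3N(Cc3ccc(F)cc3)C1=O)N2` likewise gives a limit, > 33000 nM. Compound 3 `CS(=O)(=O)Nc1ccc2c(c1)S(=O)(=O)N=C(C1=C(O)C3CCCCCCC3N(Cc3ccc(F)cc3)C1=O)N2` also gives a limit, > 33000 nM. Among the compounds with values here, compound 1 therefore stands exactly where every measured value stands, at the limit of > 33000 nM in this assay, at which 3 of the 3 values shown sit, and no step between measured compounds can be drawn from these data. Compound 4 `CC(C)N1C(=O)C(C2=NS(=O)(=O)c3cc(NS(C)(=O)=O)ccc3N2)=C(O)C2CCCC21` differs from compound 1 by isopropyl in place of (pyridin-2-yl)methyl on an amide-type nitrogen in a ring. No step beyond the usual scatter of this assay is expected from that change, so the step that the limit leaves unreadable from compound 1 to compound 4 is estimated as essentially none. Compound 4 is expected to come out near 40000 nM, in the range 20000 nM to 100000 nM, most probably again as a limit.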

Compound 4, half-maximal cytotoxic concentration: > 33000 nM
Compound 4 was reported as a limit (the forecaster's own chance of this, stated with the estimate: 85%); the middle value is on the limit's open side.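

In this assay, within the data shown here, compound 1 and compound 4 both give only a limit, so no step between them can be read: the limit of > 33000 nM in this assay, at which 4 of the 4 values shown sit. The compounds shown leave open where the half-maximal cytotoxic concentration of any of them lies, and whether isopropyl and (pyridin-2-yl)methyl differ in it.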